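This account rests on a few compounds, and the source may have more. Where it says the series, first, only, none or still open, it means among the compounds named here.

Working notes on the series. In a functional assay on A-375 cells (Homo sapiens) for antiproliferative activity, read by CCK-8 assay, with a stated time of 72 h, tested at 8 uM (a higher number here means a stronger effect of the compound at the concentration tested, a lower number a weaker effect), compound 1 `Nc1ccccc1NC(=O)c1ccc(CSC(=S)N2CCN(c3ccc(Cl)cc3)CC2)cc1` gives 29%, and compound 2 `Cc1ccc(N2CCN(C(=S)SCc3ccc(C(=O)Nc4ccccc4N)cc3)CC2)cc1` gives 26.4%. Going by the values given here, the only measured step, a number 2.6 percentage points lower from compound 1 to compound 2 (within the scatter), exchanges a single substituent on the aromatic group held on an amine nitrogen in a ring of the shared core. Compound 2 holds the lower of the two numbers, yet its gap to compound 1 lies within the scatter, so no order between the two is claimed.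

Compound 3 `Nc1ccccc1NC(=O)c1ccc(CSC(=S)N2CCN(c3ccccc3F)CC2)cc1` differs from compound 2 by 2-fluorophenyl in place of 4-methylphenyl on an amine nitrogen in a ring. The step of a number 2.6 percentage points lower from compound 1 to compound 2 (within the scatter) bears on this change, since it also varies the aromatic group on that amine nitrogen in a ring, and it stayed within the scatter. The data give no ground to expect the 2-fluorophenyl variant to behave differently, so no step beyond the scatter is expected in this assay. Compound 3 is therefore expected to give about 27%, with a range from 15% to 40%. The estimated step of a number 0.6 percentage points higher from compound 2 to compound 3 (within the scatter) is expected to stay within the scatter.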

Compound 3, a percentage reported as inhibition, at one concentration (the size of the read-out at that concentration, not a potency): 79.5%
Estimate against measurement, compound 3: 52.5 percentage points below; the measured number lies above the stated range.
By their numbers in this assay, from the lowest: compounds 2 and 1 (each within the scatter of the next); then compound 3.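

In this assay the aromatic group on an amine nitrogen in a ring can carry a large step: 2-fluorophenyl in place of 4-methylphenyl gives a number 53.1 percentage points higher from compound 2 to compound 3 (beyond the scatter) and 2-fluorophenyl in place of 4-chlorophenyl gives a number 50.5 percentage points higher from compound 1 to compound 3 (beyond the scatter) in the same series. Going by these compounds alone, the only earlier step at this position, methyl in place of chloro, stayed within the scatter, so that step did not show how much the number can move here. Nothing at hand accounts for the large steps.

The 2-fluorophenyl group differs from both 4-substituted phenyl groups in its substituent and in that substituent's place on the ring, and the compounds shown do not separate the two. A 4-fluorophenyl or a 2-chlorophenyl group on the same nitrogen would bear directly on that question.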